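Adding a sulfur-bearing side chain to compound 3

The compounds below may be only part of what the source reports. "The series", "measured", "known", "first", "only" and "open" are said of these compounds alone.

Measured so far in a functional assay on the whole organism with Mus musculus as the target, with a stated time of 90 min, at a dose of 25 umol/kg by the oral route; a lower number here means a weaker effect, a higher number a stronger effect of the compound at the dose given:
- compound 1, `O=C(CN(c1nc(Cl)nc2c1ncn2C1CCCCO1)C1CC1)N[C@@H](CC(=O)OCc1ccccc1)C(=O)OCc1ccccc1`: compound 1 gives 25.1%
- compound 2, `NC(=O)CC[C@H](NC(=O)CN(c1nc(Cl)nc2c1ncn2C1CCCCO1)C1CC1)C(=O)OCc1ccccc1`: compound 2 gives 37.8%
- compound 3, `O=C(CN(c1nc(Cl)nc2c1ncn2C1CCCCO1)C1CC1)NCC(=O)OCc1ccccc1`: compound 3 gives 25.9%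

Compound 3 stands second highest of the three numbers; it sits within the scatter of compound 1 and is separated from compound 2 by a step beyond the scatter. Compound 4, `CSCC[C@H](NC(=O)CN(c1nc(Cl)nc2c1ncn2C1CCCCO1)C1CC1)C(=O)OCc1ccccc1`, differs from compound 3 by 2-(methylsulfanyl)ethyl in place of hydrogen on a saturated chain carbon bound to an amide-type nitrogen and a carbonyl carbon.

For the measured compounds named here, two measured steps bear on this change, since both concern what sits on the same saturated chain carbon. Removing the carbamoylethyl chain gave a number 11.9 percentage points lower from compound 2 to compound 3 (beyond the scatter), while removing the benzyloxycarbonylmethyl chain gave a number 0.8 percentage points higher from compound 1 to compound 3 (within the scatter). Adding a chain to this carbon has therefore once raised the number modestly and once left it unchanged. A new chain of a different kind is expected to do something in between, at most a modest rise, and compound 4 is estimated at 31%, within 17% to 45%, meaning an expected step of a number 5.1 percentage points higher from compound 3 to compound 4 (within the scatter).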

Compound 4, a percentage reported as activity, at one dose (the size of the read-out at that dose, not a potency): 42.7%
Compound 4: middle estimate off by 11.7 percentage points, on the low side, and the stated range covers the measured number.
By their numbers in this assay, from the lowest: compounds 1 and 3 (each within the scatter of the next); then compounds 2 and 4 (each within the scatter of the next).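

In this assay, the step of a number 16.8 percentage points higher from compound 3 to compound 4 (beyond the scatter) shows that a chain on this saturated chain carbon can lift the number beyond the scatter without any carbamoyl group. Putting methylsulfanyl in place of carbamoyl gives a number 4.9 percentage points higher from compound 2 to compound 4 (within the scatter) as the step, so these two chain ends cannot be told apart here. Compound 1, with its benzyloxycarbonylmethyl chain, goes against any rule that every chain helps, and the step of a number 17.6 percentage points higher from compound 1 to compound 4 (beyond the scatter) shows that the kind of chain counts, not just its presence.

No measurement at hand explains why these chains behave differently. Going by these compounds, it also remains open whether the sulfur itself matters, and how a plain butyl chain, or a chain ending in an amine or a carboxylic acid, would compare.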